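Nonyl to phenyl in the chain on the aromatic nitrogen

This account rests on a few compounds, and the source may have more. Where it says the series, first, only, none or still open, it means among the compounds named here.

Among the compounds with values here, in a functional assay on MRC5 cells (Homo sapiens) for cytotoxicity, read by MTT assay, with a stated time of 48 h (a lower number here means a stronger inhibitor, a higher number a weaker inhibitor), compound 2 `CCCCCCCCCC[n+]1cccc(OP(=O)([O-])OC[C@H]2O[C@@H](n3cc(F)c(=O)[nH]c3=O)C[C@@H]2OC(=O)c2ccccc2)c1` gives 14100 nM, the higher of the two numbers so far, and compound 1 `C[n+]1cccc(OP(=O)([O-])OC[C@H]2O[C@@H](n3cc(F)c(=O)[nH]c3=O)C[C@@H]2OC(=O)c2ccccc2)c1` gives 5750 nM. Compound 3 `O=C(O[C@H]1C[C@H](n2cc(F)c(=O)[nH]c2=O)O[C@@H]1COP(=O)([O-])Oc1ccc[n+](Cc2ccccc2)c1)c1ccccc1` carries phenyl in place of nonyl on a saturated chain carbon bound to an aromatic nitrogen. Within the data shown here, the one measured step at this place is a 2.5-fold higher number from compound 1 to compound 2 (0.39 log units; beyond the scatter), a modest one, so a small move back toward compound 1 is expected. The expected change is a 1.6-fold lower number from compound 2 to compound 3 (0.19 log units; within the scatter), a lower number that stays within the scatter. The estimate for compound 3 is 9000 nM, with a range of 3500 nM to 23000 nM.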

Compound 3, half-maximal inhibitory concentration: 38500 nM
Beside the measured number, compound 3's estimate is 4.3-fold (0.63 log units) below it; measured number above the stated range.
By their numbers in this assay, from the lowest: compound 1; then compound 2; then compound 3.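

In this assay, the step of a 2.7-fold higher number from compound 2 to compound 3 (0.44 log units; beyond the scatter) for phenyl in place of nonyl shows that the number at this place does not follow heavy-atom count, since phenyl has fewer heavy atoms than nonyl yet reads higher. Within the data shown here, the step of a 6.7-fold higher number from compound 1 to compound 3 (0.83 log units; beyond the scatter) for phenyl in place of hydrogen is the largest seen at this place so far. No measurement shown bears on the reason for this order. Still open, on these data alone, is how a phenyl ring carrying an amine or a carboxylic acid would read. As far as these compounds go, a chain longer than decyl also remains open.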